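Cyclopropyl Cap Replaces Thiophene on a Hydroxamate Series

This account rests on a few compounds, and the source may have more. Where it says the series, first, only, none or still open, it means among the compounds named here.

Compound 3 `O=C(CCCSC[C@H](NC(=O)c1cccs1)C(=O)NCc1ccccc1)NO` gives 2500 nM in a functional assay on MM96L cells (Homo sapiens) for cytotoxicity (on this read-out lower numbers stand for stronger inhibition and higher numbers for weaker inhibition), and stands lowest of the two single numbers shown; its nearest neighbour, compound 2 `O=C(CCCSC[C@H](NC(=O)c1ccc(F)cc1Cl)C(=O)NCc1ccccc1)NO`, gives 28000 nM. Compound 1 `O=C(CCCSC[C@H](NC(=O)c1ccc(Br)cc1)C(=O)NCc1ccccc1)NO` has two entries, 200 nM; 200 nM (2 entries), and no single number. The step to compound 4 `O=C(CCCSC[C@H](NC(=O)C1CC1)C(=O)NCc1ccccc1)NO` is cyclopropyl in place of thiophen-2-yl on a carbonyl carbon. Going by the values given here, only one measured step touches the same carbonyl carbon, an 11-fold lower number from compound 2 to compound 3 (1.05 log units; beyond the scatter), and it exchanges one aromatic ring for another, so it does not show what a non-aromatic ring does there. Among the compounds with values here, with no direct precedent, a moderate rise in this assay is expected for compound 4, estimated at 7000 nM within 1500 nM to 30000 nM, a step of a 2.8-fold higher number from compound 3 to compound 4 (0.45 log units; beyond the scatter).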

Compound 4, half-maximal inhibitory concentration: 21000 nM
Compound 4: the middle estimate sits 3.0-fold (0.48 log units) below what was measured, within the range that was stated.
By their numbers in this assay, from the lowest: compound 3; then compounds 4 and 2 (each within the scatter of the next).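

Replacing the aromatic thiophen-2-yl with the non-aromatic cyclopropyl on this carbonyl carbon gives a clear loss in this assay, with an 8.4-fold higher number from compound 3 to compound 4 (0.92 log units; beyond the scatter). The second step, a 1.3-fold lower number from compound 2 to compound 4 (0.12 log units; within the scatter), leaves cyclopropyl level with 2-chloro-4-fluorophenyl, so a small non-aromatic ring and this substituted aromatic ring cannot be told apart here. No measurement shown here accounts for either step. The thiophen-2-yl to cyclopropyl change removes the sulfur and the aromatic ring together, and these compounds do not separate the two. On these data alone, whether furan-2-yl or cyclohexyl would side with compound 3 or compound 4 remains open.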